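Swapping the Formylphenyl Arm for a Thiophene Ring

The compounds below may be only part of what the source reports. "The series", "measured", "known", "first", "only" and "open" are said of these compounds alone.

Compound 1, `O=Cc1ccc(-c2cn3ccnc3c(-c3ccc4ncn(C5CCCCC5)c4c3)n2)cc1`: 46.9%
Compound 2, `Fc1ccc(-c2cn3ccnc3c(-c3ccc4ncn(C5CCCCC5)c4c3)n2)cc1`: 3.5%
Compound 3, `Brc1ccc(-c2cn3ccnc3c(-c3ccc4ncn(C5CCCCC5)c4c3)n2)cc1`: 30.7%

Three compounds share one core and differ only in the group on the outer aromatic ring. In a functional assay on LOX IMVI cells (Homo sapiens) for inhibition, read by sulforhodamine B assay, with a stated time of 48 h, tested at 10 uM (on this read-out lower numbers stand for less inhibition and higher numbers for more inhibition at the one concentration tested (going by the name of the read-out)), compound 1 stands highest of the three numbers. Both measured steps away from it go down: a number 16.2 percentage points lower from compound 1 to compound 3 (beyond the scatter), and a number 43.4 percentage points lower from compound 1 to compound 2 (beyond the scatter). Between the two halogen compounds, a number 27.2 percentage points higher from compound 2 to compound 3 (beyond the scatter).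

Compound 4, `c1csc(-c2cn3ccnc3c(-c3ccc4ncn(C5CCCCC5)c4c3)n2)c1`, is not yet measured. It differs from compound 1 as follows: thiophen-2-yl in place of 4-formylphenyl on an aromatic carbon. In both measured steps the formyl left and the inhibition fell; here the formyl leaves as well, but the whole six-membered ring is replaced by a five-membered one, so the measured steps bear on the change only in part. A drop beyond the scatter is nevertheless expected, a number 26.9 percentage points lower from compound 1 to compound 4 (beyond the scatter), of a size between the modest and the large steps seen. The estimate for compound 4 is therefore 20%, with a range from 2% to 42%.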

Compound 4, a percentage reported as inhibition, at one concentration (the size of the read-out at that concentration, not a potency): 1.07%
Compound 4: middle estimate off by 18.9 percentage points, on the high side; the whole stated range lies above it.
By their numbers in this assay, from the lowest: compounds 4 and 2 (each within the scatter of the next); then compound 3; then compound 1.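

In this assay, the change of the whole arm, thiophen-2-yl in place of 4-formylphenyl, gives a number 45.8 percentage points lower from compound 1 to compound 4 (beyond the scatter) and, set against the bromo arm, a number 29.6 percentage points lower from compound 3 to compound 4 (beyond the scatter) at this position on the shared core. The comparison with the fluoro arm gives a number 2.4 percentage points lower from compound 2 to compound 4 (within the scatter), so a five-membered ring and 4-fluorophenyl sit together at the low end, and keeping the six-membered ring does not by itself preserve inhibition. No measurement here explains why these arms differ.

Whether the thiophene ring itself or the missing formyl accounts for the low number stays open, and a thiophene carrying a formyl group would separate the two. Also open, as far as these compounds go, is how a 4-aminophenyl or 4-carboxyphenyl arm would compare with 4-formylphenyl at this position.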